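A few compounds are considered here, and "the series" means these few. Any claim that something is new, unique, unknown or untested is made for them only; others in the source may bear on it.

Compound 1 `O=C(NCCCCc1cccnc1)c1ccc(-c2cccc(O)c2)cc1` is the weakest binder among the three compounds measured here. In an assay (Canis lupus familiaris) for binding affinity to platelet-activating factor receptor (Homo sapiens), read by radioligand binding (a higher number here means a weaker inhibitor, a lower number a stronger inhibitor), compound 1 gives 300 nM, the highest of the three numbers. Compound 3 `O=C(NCCCCc1cccnc1)c1ccc(-c2ccccc2)c(-c2ccccc2)c1` gives 5 nM in this assay, and compound 2 `CCCCc1cc(C(=O)N[C@H](C)CCCc2cccnc2)ccc1-c1ccc(OC)c(OC)c1` gives 4 nM; both of these differences from compound 1 lie well beyond the usual scatter, while compound 2 and compound 3 are within scatter of each other. Going by the values given here, compound 2 and compound 3 differ from compound 1 in more than one place, so no single step between measured compounds can be read from them.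

Compound 4 `Cc1ccc(-c2ccc(C(=O)NCCCCc3cccnc3)cc2)cc1C` has not yet been measured. It differs from compound 1 in one place only: 3,4-dimethylphenyl in place of 3-hydroxyphenyl on an aromatic carbon. Because compound 1 sits at 300 nM while compound 2 gives 4 nM and compound 3 gives 5 nM, both of them carrying groups without a hydroxyl, the step is expected to move toward a lower number, beyond the scatter, by roughly a 7.5-fold lower number from compound 1 to compound 4 (0.88 log units; beyond the scatter). For compound 4 the expected value in this assay is 40 nM, within a range of 10 nM to 150 nM.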

Compound 4, half-maximal inhibitory concentration: 200 nM
Compound 4: middle estimate off by 5.0-fold (0.70 log units), on the low side; measured number outside the range, above it.
By their numbers in this assay, from the lowest: compounds 2 and 3 (each within the scatter of the next); then compounds 4 and 1 (each within the scatter of the next).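

In this assay, 3,4-dimethylphenyl in place of 3-hydroxyphenyl, at a place para to a large group, gives a 1.5-fold lower number from compound 1 to compound 4 (0.18 log units; within the scatter). Going by these compounds alone, removing the hydroxyl and adding the two methyl groups together therefore does not produce a step beyond the scatter at this position, something the earlier compounds could not show, as compound 2 and compound 3 differ from compound 1 in more than one place. Nothing given here explains this outcome.

The compounds shown do not separate the loss of the hydroxyl from the gain of the two methyl groups, and they do not reveal which of the several differences in compound 2 or compound 3 goes with their low numbers. From the compounds shown here alone, whether an amine or a carboxylic acid on this phenyl ring would give a step beyond the scatter also remains open.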